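This account rests on a few compounds, and the source may have more. Where it says the series, first, only, none or still open, it means among the compounds named here.

Measured in a functional assay on U2OS cells (Homo sapiens) for cytotoxicity, read by MTT assay, with a stated time of 48 h; on this read-out lower numbers stand for stronger inhibition and higher numbers for weaker inhibition:
- compound 1 `Fc1ccc2nc(-c3ccccc3)nc(Nc3ccccc3)c2c1`: > 50000 nM (a limit)
- compound 2 `Fc1cccc(Nc2nc(-c3cccc(F)c3)nc3ccc(F)cc23)c1`: 49600 nM
- compound 3 `Fc1cccc(-c2nc(Nc3cccc(Cl)c3)c3cc(F)ccc3n2)c1`: > 50000 nM (a limit)

Compound 2 is the only one of the three with a true number. The other two rest on (the limit of > 50000 nM in this assay, at which 2 of the 3 values shown sit). For the measured compounds named here, the one measured step, a number no lower from compound 2 to compound 3 (the limit leaves the size open), puts chloro in place of fluoro on an aromatic carbon, and its size cannot be read.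

Compound 4 `Oc1ccc(Nc2nc(-c3cccc(F)c3)nc3ccc(F)cc23)cc1` differs from compound 2 as follows: 4-hydroxyphenyl in place of 3-fluorophenyl on a nitrogen on an aromatic ring. That is, 4-hydroxyphenyl stands in place of 3-fluorophenyl on a nitrogen on an aromatic ring. Going by the values given here, no measured step gives a size to carry over, so the expectation in this assay is loose: a modest move toward stronger inhibition, or none. The expected change is a 2.5-fold lower number from compound 2 to compound 4 (0.39 log units; beyond the scatter). Compound 4 is estimated at 20000 nM, with an expected range of 4000 nM to 50000 nM.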

Compound 4, half-maximal inhibitory concentration: > 50000 nM
Compound 4 gave a limit, no number; the forecaster's own chance of this, stated with the estimate: 30%; at least 2.5-fold (0.39 log units) between middle value and limit.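

In this assay compound 4 gives > 50000 nM, which is a limit and not a number. On a nitrogen on an aromatic ring, 4-hydroxyphenyl adds a hydrogen-bond donor and acceptor that 3-fluorophenyl lacks, yet the outcome is a number no lower from compound 2 to compound 4 (the limit leaves the size open) and no more. The steps to compound 4 cannot be read, so the size of the change stays unknown, and the series offers little to compare: the limit of > 50000 nM in this assay, at which 3 of the 4 values shown sit.

From the compounds shown here alone, it remains open whether 4-aminophenyl or 4-carboxyphenyl on this nitrogen would give a true number in this assay.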